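Cyano removal on the methoxyphenoxy fragment: step yet unmeasured

This account rests on a few compounds, and the source may have more. Where it says the series, first, only, none or still open, it means among the compounds named here.

Measured so far:
compound 1, `COc1cc(C(C)=O)ccc1OCCCN1CCC(C(c2ccc(F)cc2)c2ccccn2)CC1`: 158 nM
compound 2, `COc1cc(C#N)ccc1OCCCN1CCC(C(c2ccc(F)cc2)c2ccc(F)cc2)CC1`: 2 nM

In a functional assay (aorta) with Oryctolagus cuniculus as the target (a lower number here means tighter binding, a higher number weaker binding), compound 2 gives 2 nM, the lowest of the two numbers. The nearest is compound 1, which gives 158 nM, a gap well beyond the scatter. Compound 1 and compound 2 differ in more than one place, so no single change between them is known; only the two values stand side by side.

Compound 3, `COc1ccccc1OCCCN1CCC(C(c2ccc(F)cc2)c2ccc(F)cc2)CC1`, is not yet measured. It differs from compound 2 in one place: hydrogen in place of cyano on an aromatic carbon. Within the data shown here, no step between two measured compounds differing in one place exists, so the size of this step is open. The comparison of compound 1 with compound 2 shows that several changes together go with a large gap, but that gap cannot be divided among them.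

In this assay a weakening is expected: the step from compound 2 to compound 3 is estimated at a 4.0-fold higher number from compound 2 to compound 3 (0.60 log units; beyond the scatter), beyond the scatter yet far smaller than the gap to compound 1. Compound 3 is expected to give 8 nM, within 2 nM to 40 nM.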

Compound 3, dissociation constant: 2.51 nM
Beside the measured number, compound 3's estimate is 3.2-fold (0.50 log units) above it, within the range that was stated.
By their numbers in this assay, from the lowest: compounds 2 and 3 (each within the scatter of the next); then compound 1.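

In this assay, putting hydrogen in place of cyano on the aromatic carbon para to a large group gives a 1.3-fold higher number from compound 2 to compound 3 (0.10 log units; within the scatter) and so stays within the scatter. Among these compounds, this is the first single-place reading: on the core of compound 2, the 4-cyano-2-methoxyphenoxy and 2-methoxyphenoxy ends cannot be told apart in this read-out, so the low nanomolar value of compound 2 does not depend on the cyano group. No accompanying data bear on why this change leaves the value within the scatter.

From the compounds shown here alone, the reading covers only cyano and hydrogen on this one core, so the large gap separating compound 1 from compound 2 remains undivided among their several differences, and the contribution of the acetyl group of compound 1 at this position remains unknown. Also open, going by these compounds, is whether a carboxylic acid, an aminomethyl group or a longer chain on the same aromatic carbon would stay within the scatter of compound 3 or move the value beyond it.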